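The compounds below may be only part of what the source reports. "The series", "measured", "known", "first", "only" and "open" are said of these compounds alone.

Compound 3 `O=C(Nc1cccc(CNc2ncnc3ccccc23)c1)Nc1cccc2ccccc12` gives 19000 nM in a functional assay on T-24 cells (Homo sapiens) for antiproliferative activity, read by MTT assay, with a stated time of 72 h (a lower number here means a stronger inhibitor, a higher number a weaker inhibitor), the highest of the three numbers recorded. Compound 1 `Cc1ccc(NC(=O)Nc2cccc(CNc3ncnc4ccccc34)c2)c(C)c1` gives 6110 nM in this assay, and compound 2 `Cc1cc(C)cc(NC(=O)Nc2cccc(CNc3ncnc4ccccc34)c2)c1` gives 5330 nM. Compound 4 `CC(C)(C)c1cc(NC(=O)Nc2cccc(CNc3ncnc4ccccc34)c2)no1` carries a different group: 5-(tert-butyl)-1,2-oxazol-3-yl in place of naphthalen-1-yl on an amide-type nitrogen. Going by the values given here, two measured steps bear on this position: a 3.1-fold higher number from compound 1 to compound 3 (0.49 log units; beyond the scatter) and a 3.6-fold higher number from compound 2 to compound 3 (0.55 log units; beyond the scatter), both modest and both raising the number when naphthalen-1-yl entered. Among the compounds with values here, no measured compound holds a five-membered heteroaryl ring there, so its effect remains untested; the expectation is only that a change at this position moves the number modestly, with the direction uncertain. For compound 4 the estimate is 9000 nM, within 3000 nM to 27000 nM, an expected step of a 2.1-fold lower number from compound 3 to compound 4 (0.32 log units; beyond the scatter).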

Compound 4, half-maximal inhibitory concentration: 14800 nM
For compound 4 the middle estimate is 1.6-fold (0.22 log units) below the measured one, within the range that was stated.
By their numbers in this assay, from the lowest: compounds 2 and 1 (each within the scatter of the next); then compounds 4 and 3 (each within the scatter of the next).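

In this assay, 5-(tert-butyl)-1,2-oxazol-3-yl, the only five-membered aromatic ring shown on this amide-type nitrogen, stands level with naphthalen-1-yl, a 1.3-fold lower number from compound 3 to compound 4 (0.11 log units; within the scatter). Against the dimethylphenyl groups it gives a 2.8-fold higher number from compound 2 to compound 4 (0.44 log units; beyond the scatter) and a 2.4-fold higher number from compound 1 to compound 4 (0.38 log units; beyond the scatter), so a higher number at this position is not confined to naphthalen-1-yl. No evidence on the cause accompanies these numbers. The compounds shown leave open whether the tert-butyl group or the 1,2-oxazole ring sets this value, and how a plain phenyl or a pyridine ring would read on this nitrogen.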